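Aryl swap at the chain end: compound 3

The compounds below may be only part of what the source reports. "The series", "measured", "known", "first", "only" and "open" are said of these compounds alone.

In a functional assay on Caco-2 cells (Homo sapiens) for antiproliferative activity, read by sulforhodamine B assay, with a stated time of 2 days (on this read-out lower numbers stand for stronger inhibition of growth and higher numbers for weaker inhibition of growth), compound 1 `COc1ccc(/C=C/C(=O)NCCCCNc2ccnc3cc(Cl)ccc23)cc1` gives 30700 nM, and compound 2 `O=C(/C=C/c1ccc(F)cc1)NCCCCNc1ccnc2cc(Cl)ccc12` gives 15000 nM, the lowest of the two numbers shown; the step of a 2.0-fold lower number from compound 1 to compound 2 (0.31 log units; beyond the scatter) is the only measured comparison in the series. Compound 3 `O=C(/C=C/c1cccc([N+](=O)[O-])c1)NCCCCNc1ccnc2cc(Cl)ccc12` differs from compound 2 by 3-nitrophenyl in place of 4-fluorophenyl on a double-bonded chain carbon bound to a double-bonded chain carbon. Going by the values given here, the one measured step concerns a different exchange on that ring and offers no direct guide for a nitro group, so only a small change is expected, a 1.1-fold higher number from compound 2 to compound 3 (0.05 log units; within the scatter), not clearly beyond the scatter. The estimate for compound 3 in this assay is 17000 nM, with a range from 6000 nM to 45000 nM.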

Compound 3, concentration for 50% growth inhibition: 19300 nM
Compound 3: middle estimate off by 1.1-fold (0.06 log units), on the low side; low and high end bracket the measured number.
By their numbers in this assay, from the lowest: compounds 2, 3 and 1 (each within the scatter of the next, the first and the last beyond it).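

In this assay, 3-nitrophenyl on a double-bonded chain carbon bound to a double-bonded chain carbon cannot be told apart from either earlier aryl group: a 1.3-fold higher number from compound 2 to compound 3 (0.11 log units; within the scatter) and a 1.6-fold lower number from compound 1 to compound 3 (0.20 log units; within the scatter) both stay within the scatter. This place therefore tolerates a nitro group, and of the three compounds only compound 1 and compound 2 remain separated beyond the scatter. Nothing available speaks to a cause for this.

As far as these compounds go, whether an aryl ring bearing an amine or a carboxylic acid would give a number beyond the scatter of these three stays open.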